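Shift from methyl to methoxy raises remaining compound

A few compounds are considered here, and "the series" means these few. Any claim that something is new, unique, unknown or untested is made for them only; others in the source may bear on it.

A set of three compounds shares a core and was tested in an ADME assay on liver (Mus musculus) for metabolic stability, read by LC-MS, using microsomes and NADPH; a higher number here means that more of the compound is left, a lower number that less of the compound is left. Compound 1 `Cc1cc(CN(CC2CC2)C(CC(=O)O)c2ccc(Cl)cc2)ccc1OCCn1c(=O)ccn(C)c1=O` leaves 24%. Compound 2 `Cc1cc(CN(C2CCC2)C(CC(=O)O)c2ccc(Cl)cc2)ccc1OCCn1c(=O)ccn(C)c1=O` leaves 22%. Compound 3 `COc1cc(CN(CC2CC2)C(CC(=O)O)c2ccc(Cl)cc2)ccc1OCCn1c(=O)ccn(C)c1=O` leaves 42%, the highest of the three numbers, beyond the scatter against both others.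

Two changes connect them. From compound 1 to compound 2 the change is cyclobutyl in place of cyclopropylmethyl on an amine nitrogen, and in this assay it made a number 2 percentage points lower from compound 1 to compound 2 (within the scatter). From compound 1 to compound 3 the change is methoxy in place of methyl on an aromatic carbon, and in this assay it made a number 18 percentage points higher from compound 1 to compound 3 (beyond the scatter).

Compound 4 `COc1cc(CN(C2CCC2)C(CC(=O)O)c2ccc(Cl)cc2)ccc1OCCn1c(=O)ccn(C)c1=O` has not yet been measured in this assay. It differs from compound 3 by cyclobutyl in place of cyclopropylmethyl on an amine nitrogen, the same change as that from compound 1 to compound 2, at a place described in identical terms. Because that earlier change made a number 2 percentage points lower from compound 1 to compound 2 (within the scatter), compound 4 is expected to leave about as much as compound 3, with a number 2 percentage points lower from compound 3 to compound 4 (within the scatter) estimated. The estimate for compound 4 in this assay is 40%, expected between 28% and 52%.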

Compound 4, percent of the compound remaining: 51%
For compound 4 the middle estimate is 11 percentage points below the measured one, within the range that was stated.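

In this assay, cyclobutyl in place of cyclopropylmethyl on an amine nitrogen gave a number 9 percentage points higher from compound 3 to compound 4 (within the scatter), so this change carried from one core to the other without a difference that can be told from the scatter: the same change on two cores in this assay, a number 2 percentage points lower (within the scatter) from compound 1 to compound 2 and a number 9 percentage points higher (within the scatter) from compound 3 to compound 4, 11 percentage points apart, within the scatter of two such steps. Methoxy in place of methyl on an aromatic carbon gave a number 29 percentage points higher from compound 2 to compound 4 (beyond the scatter), and it too carried over, remaining beyond the scatter on both cores: the same change on two cores in this assay, a number 18 percentage points higher (beyond the scatter) from compound 1 to compound 3 and a number 29 percentage points higher (beyond the scatter) from compound 2 to compound 4, 11 percentage points apart, within the scatter of two such steps. This shows that the two changes behaved consistently across these four compounds, but each comparison rests on a single pair of steps, so it does not show that either change would transfer to a further core, and it does not explain either result.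

The compounds shown leave open how an ethoxy group on that aromatic carbon, or a cyclopentyl group or longer chain on the amine nitrogen, would fare. They also leave open whether the pattern would persist with an amide in place of the carboxylic acid.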